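The compounds below may be only part of what the source reports. "The series", "measured", "known", "first", "only" and "open" are said of these compounds alone.

Working notes on the series. Compound 1 `CC(C)OC(=O)N1CCC(Oc2cccc3c2CCN3c2ccc(S(C)(=O)=O)cc2)CC1` gives 501 nM in a functional assay on CHO-K1 cells for agonist activity at Glucose-dependent insulinotropic receptor (Homo sapiens), read by a luciferase reporter, with a stated time of 5 h; a lower number here means that less compound is needed, a higher number that more compound is needed for the effect. Compound 2 `CC(C)OC(=O)N1CCC(Oc2ncnc3c2CCN3c2ccc(C#N)cc2F)CC1` gives 63.1 nM in this assay, and compound 3 `CC(C)OC(=O)N1CCC(Oc2ncnc3c2CCN3c2ccc(-c3cccn3C)cc2F)CC1` gives 158 nM in this assay. Among the compounds with values here, compound 2 stands lowest of the three numbers: the step of a 2.5-fold higher number from compound 2 to compound 3 (0.40 log units; beyond the scatter) is beyond the scatter, and compound 1 lies further off still, though compound 1 differs from compound 2 in more than one place, so no single step is drawn between those two.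

Compound 4 `CC(C)OC(=O)N1CCC(Oc2ncnc3c2CCN3c2ccc(C#N)c(F)c2)CC1` is not yet measured. Its change from compound 2 is 4-cyano-3-fluorophenyl in place of 4-cyano-2-fluorophenyl on a nitrogen on an aromatic ring in a ring; the two have the same atoms joined differently, the fluorine alone moving on the ring that carries the nitrile. Within the data shown here, no measured step bears directly on this change. The one step shown, a 2.5-fold higher number from compound 2 to compound 3 (0.40 log units; beyond the scatter), swaps the group at the cyano position on that ring and leaves the 4-cyano-2-fluorophenyl arrangement untouched, and that arrangement is the only one seen in compound 2 and compound 3. The data therefore give no direction for the move of the fluorine, and the expected step of a 1.7-fold higher number from compound 2 to compound 4 (0.24 log units; within the scatter) is set modest, with a wide range around it. Compound 4 is expected to give 110 nM in this assay, between 35 nM and 350 nM.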

Compound 4, half-maximal effective concentration: 398 nM
For compound 4 the middle estimate is 3.6-fold (0.56 log units) below the measured one; measured number above the stated range.
By their numbers in this assay, from the lowest: compound 2; then compound 3; then compounds 4 and 1 (each within the scatter of the next).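

In this assay the placing of the fluorine on the ring that carries the nitrile turns out to matter: the step of a 6.3-fold higher number from compound 2 to compound 4 (0.80 log units; beyond the scatter) lies beyond the scatter, although the two compounds have the same atoms, joined differently. Within the data shown here, until now the only single-place change was the exchange of the cyano group for 1-methyl-1H-pyrrol-2-yl, the step of a 2.5-fold higher number from compound 2 to compound 3 (0.40 log units; beyond the scatter), which left the fluorine where it stood, so the new step is the first reading on the fluorine itself, and within these compounds 4-cyano-2-fluorophenyl on the ring nitrogen is the better-placed of the two arrangements. Nothing measured in this set accounts for the difference between the two arrangements.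

Open, from the compounds shown here alone, is how a phenyl ring carrying the nitrile and no fluorine, or one with a chlorine atom or a methoxy group in place of the fluorine, would stand against compound 2. Also open, going by these compounds, is whether the same move of the fluorine would give a step of similar size when 1-methyl-1H-pyrrol-2-yl replaces the nitrile, as in compound 3.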